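A few compounds are considered here, and "the series" means these few. Any claim that something is new, unique, unknown or untested is made for them only; others in the source may bear on it.

Of the compounds shown here, three have so far been tested in a functional assay on Malme-3M cells (Homo sapiens) for cytotoxicity, read by sulforhodamine B assay, with a stated time of 48 h, tested at 10 uM; a lower number here means a stronger effect, a higher number a weaker effect of the compound at the concentration tested. Compound 1 `COc1ccc(-c2cc(/C=C/C(=O)c3ccc(N)cc3)[nH]n2)cc1` gives -23% in this assay. Compound 3 `COc1ccc(-c2cc(/C=C/C(=O)c3ccc(N)cc3)[nH]n2)cc1OC` gives 37% in this assay, and the step of a number 60 percentage points higher from compound 1 to compound 3 (beyond the scatter) is the result of one change, namely (methoxy in place of hydrogen on an aromatic carbon). Compound 2 `COc1ccc(C(=O)/C=C/c2cc(-c3cc(OC)c(OC)c(OC)c3)n[nH]2)cc1OC` gives -82% in this assay, the lowest of the three numbers; its difference from compound 1 is not broken down here, as the two cores differ in more than one place.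

Compound 4 `COc1cc(C(=O)/C=C/c2cc(-c3cc(OC)c(OC)c(OC)c3)n[nH]2)cc(OC)c1OC` has not yet been measured in this assay. It differs from compound 2 by methoxy in place of hydrogen on an aromatic carbon. The surroundings of the place are not identical to those in the earlier pair: in compound 4 the entering methoxy group is also meta to a methoxy group, so this is the same kind of change as that from compound 1 to compound 3, not the same change. Among the compounds with values here, the only measured step of this kind is a number 60 percentage points higher from compound 1 to compound 3 (beyond the scatter), which is large and beyond the scatter.

For compound 4 a step of about a number 52 percentage points higher from compound 2 to compound 4 (beyond the scatter) is expected in this assay, because the step of a number 60 percentage points higher from compound 1 to compound 3 (beyond the scatter) was large and a weaker version of it is assumed here given the different surroundings. Compound 4 is therefore estimated to give about -30% in this assay. For compound 4 the expected range runs from -75% to 15%.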

Compound 4, a percentage reported as activity, at one concentration (the size of the read-out at that concentration, not a potency): -57%
For compound 4 the middle estimate is 27 percentage points above the measured one; measured number inside the range.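

The change of methoxy in place of hydrogen on an aromatic carbon moved the number the same way on both cores in this assay: with the new step, a number 25 percentage points higher from compound 2 to compound 4 (beyond the scatter), the effect at the concentration tested again becomes weaker. The direction therefore carried over from one core to the other, but the size did not: the same change on two cores in this assay, a number 60 percentage points higher (beyond the scatter) from compound 1 to compound 3 and a number 25 percentage points higher (beyond the scatter) from compound 2 to compound 4, 35 percentage points apart, beyond the scatter of two such steps So the earlier step gives a fair guide to the sign of this change in these two pairs, but not to how large it will be, and two pairs are too few to make a rule for any further core; nor can they separate the part played by the core from the part played by the surroundings of the place, as the entering methoxy group sits differently in the two pairs.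

The compounds shown leave open whether an ethoxy group or a hydroxy group at the same place would move the number as methoxy does. They also leave open how the same change would behave on a core carrying a carboxylic acid where compound 1 carries its amine.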